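The source may hold more compounds than are shown below. What is called first, only, known or untested is meant among the compounds shown, and "the series" means these compounds.

Of the compounds shown here, two that share one core have so far been tested in a functional assay on SK-BR-3 cells (Homo sapiens) for inhibition, read by CellTiter-Glo, with a stated time of 72 h; a higher number here means a weaker inhibitor, a lower number a stronger inhibitor. Compound 1 `CC(C)c1nn(-c2ccc(C(N)=O)c(N[C@H]3CC[C@H](O)CC3)c2)c2nccc(-n3cnc(-c4ccncc4)c3)c12` gives 165 nM in this assay, and compound 2 `CC(C)c1nn(-c2ccc(C(N)=O)c(N[C@H]3CC[C@H](O)CC3)c2)c2cccc(-c3cnc4ccccc4c3)c12` gives 39 nM. Compound 1 thus has the higher of the two numbers, making it the weaker inhibitor of the pair, and the gap to compound 2 lies beyond the scatter of repeated measurements. Compound 3 `CC(C)c1nn(-c2ccc(C(N)=O)c(N[C@H]3CC[C@H](O)CC3)c2)c2nccc(-c3ccc4ccccc4c3)c12` has not yet been measured. It differs from compound 1 in one place: naphthalen-2-yl in place of 4-(pyridin-4-yl)-1H-imidazol-1-yl on an aromatic carbon. Compound 2 also carries a two-ring aromatic group on its core, but that core itself differs from the core of compound 1, so no single-change comparison is available. Even so, the lower number of compound 2 in this assay, 39 nM, hints that a two-ring aromatic group can go together with stronger inhibition. The step is therefore expected to be a 2.8-fold lower number from compound 1 to compound 3 (0.44 log units; beyond the scatter), a moderate move toward stronger inhibition, held with considerable uncertainty. Compound 3 is estimated at 60 nM in this assay, within a range from 15 nM to 250 nM.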

Compound 3, half-maximal inhibitory concentration: > 10000 nM
Compound 3: a limit, no number; the forecaster's own chance of this, stated with the estimate: 3%; at least 160-fold (2.22 log units) between middle value and limit.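

Compound 3 stands in this assay at a limit of the assay, not at a number: the limit of > 10000 nM in this assay, at which 1 of the 3 values shown sits. Replacing 4-(pyridin-4-yl)-1H-imidazol-1-yl with naphthalen-2-yl on this aromatic carbon, opposite the ring nitrogen, gives an at least 60-fold higher number from compound 1 to compound 3 (1.78 log units; beyond the scatter), so a change in this one place on the shared core is enough to move the result out of the measurable range of this assay. The heavy-atom count barely moves between the group that leaves and the one that enters while the result moves greatly, and the clearest difference on paper is that the entering group is carbon only, with no hydrogen-bond acceptors.

This single pair cannot tell whether the loss of inhibition goes with the missing nitrogens, with the different arrangement of the rings, or with both. A phenyl group or 1H-imidazol-1-yl alone on the same carbon, or a two-ring aromatic group that contains nitrogen, such as quinolin-3-yl, would help to separate these possibilities on this core.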